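Decyl chain in place of methoxyphenyl: compound 3

The source may report more compounds than this note shows. Statements on the series, on what has been measured and on what is new or still open speak of the compounds shown alone.

Compound 1 `CCCCCc1ccc(-c2cn(C[C@H](O)[C@H]3OC(=O)C(OCc4ccccc4)=C3OCc3ccccc3)nn2)cc1` and compound 2 `COc1ccccc1-c1cn(C[C@H](O)[C@H]2OC(=O)C(OCc3ccccc3)=C2OCc2ccccc2)nn1` share one core and differ only in the group on an aromatic carbon. In a functional assay on A549 cells (Homo sapiens) for antiproliferative activity, read by MTT assay, with a stated time of 72 h (a lower number here means a stronger inhibitor, a higher number a weaker inhibitor), compound 1 gives 6220 nM. For compound 2 this assay reports only a limit, > 100000 nM. The step of an at least 16-fold higher number from compound 1 to compound 2 (1.20 log units; beyond the scatter) is accordingly large, and compound 2 stands at the weak end of the numbers shown, placed by the limit of > 100000 nM in this assay, at which 1 of the 2 values shown sits, rather than by a measured value.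

Compound 3 `CCCCCCCCCCc1cn(C[C@H](O)[C@H]2OC(=O)C(OCc3ccccc3)=C2OCc2ccccc2)nn1` is the next step: decyl in place of 2-methoxyphenyl on an aromatic carbon. Among the compounds with values here, only one measured step bears on it, an at least 16-fold higher number from compound 1 to compound 2 (1.20 log units; beyond the scatter), in which 4-pentylphenyl gave way to 2-methoxyphenyl and the number rose out of range. Within the data shown here, compound 3 moves the other way, from 2-methoxyphenyl to an open decyl chain without ring or acceptor; no measured pair compares an aromatic group with a plain chain, so a return toward the range of compound 1 is expected in direction but not with certainty in size. Compound 3 is therefore expected to leave the limit, at an estimated 10000 nM, between 3000 nM and 60000 nM. The step of an at least 10-fold lower number from compound 2 to compound 3 (1.00 log units; beyond the scatter) is expected to be a fall in the number.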

Compound 3, half-maximal inhibitory concentration: 6750 nM
Compound 3: the middle estimate sits 1.5-fold (0.17 log units) above what was measured; the measured number falls inside the stated range.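

In this assay, the aromatic carbon of the five-membered aromatic ring with 3 nitrogen accepts a group with no ring at all, and a 1.1-fold higher number from compound 1 to compound 3 (0.04 log units; within the scatter) leaves decyl and 4-pentylphenyl indistinguishable in this series. An aromatic ring at this position is therefore not required to reach the activity of compound 1, and the weak reading of compound 2 does not extend to every replacement of 4-pentylphenyl, since an at least 14-fold lower number from compound 2 to compound 3 (1.17 log units; beyond the scatter). The size of that step is only a lower bound, as compound 2 is held by a limit and not by a measured number: the limit of > 100000 nM in this assay, at which 1 of the 3 values shown sits.

Among the three compounds, the two with readings inside the range both carry an alkyl chain, but the series does not separate the absence of such a chain in compound 2 from the presence of its methoxy oxygen or the place of that group on the ring. Unsubstituted phenyl, 4-methoxyphenyl, a shorter chain such as butyl, or a decyl chain ending in an amine or a carboxylic acid would each bear on these open points.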